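The source may hold more compounds than are shown below. What is called first, only, known or untested is meant among the compounds shown, and "the series" means these compounds.

In an ADME assay on HEK293 cells (Homo sapiens) for cytotoxicity, with a stated time of 6 h (a lower number here means that less compound is tolerated, a higher number that more compound is tolerated), three compounds sharing one core have been measured. Compound 1 `CCCCNc1nc(N)nc2cccc(Cl)c12`, which carries chloro, gives 100 nM. Compound 2 `CCCCNc1nc(N)nc2cccc(CC3CCCC3)c12`, which carries cyclopentylmethyl, shows > 25000 nM, and this is a limit of the assay and not a number. Compound 3 `CCCCNc1nc(N)nc2cccc(OCCOC)c12`, which carries 2-methoxyethoxy, gives 10000 nM, the higher of the two actual numbers and far from compound 1.

Compound 4 `CCCCNc1nc(N)nc2cccc(C(=O)NC)c12`, not yet measured, has methylcarbamoyl in place of 2-methoxyethoxy on an aromatic carbon. Within the data shown here, three measured steps bear on this change. Replacing chloro produced two large steps, an at least 250-fold higher number from compound 1 to compound 2 (2.39 log units; beyond the scatter) and a 100-fold higher number from compound 1 to compound 3 (2.00 log units; beyond the scatter). Exchanging one of those replacement groups for the other produced a much smaller one, an at least 2.5-fold lower number from compound 2 to compound 3 (0.39 log units; beyond the scatter). Compound 4 also lacks chloro, so compound 3 is taken as its closest guide.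

No step beyond the scatter is therefore expected, and the estimated step is a 1.2-fold higher number from compound 3 to compound 4 (0.08 log units; within the scatter). Compound 4 is expected at 12000 nM, with an estimated range from 3000 nM to 25000 nM.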

Compound 4, half-maximal cytotoxic concentration: > 25000 nM
Compound 4 gave a limit, no number; the forecaster's own chance of this, stated with the estimate: 20%; middle value at least 2.0-fold (0.31 log units) away from the limit.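

In this assay, the exchange of 2-methoxyethoxy for methylcarbamoyl on this aromatic carbon is not a silent one, as it gives an at least 2.5-fold higher number from compound 3 to compound 4 (0.39 log units; beyond the scatter). Methylcarbamoyl is also the third group in place of chloro to give a large step, here an at least 250-fold higher number from compound 1 to compound 4 (2.39 log units; beyond the scatter), so among the four compounds, compound 1 alone has a number close to the low end and every replacement tolerated far more compound. The step between compound 2 and compound 4 cannot be read, because each of the two gave a limit of the assay and not a number: the limit of > 25000 nM in this assay, at which 2 of the 4 values shown sit.

From the compounds shown here alone, how cyclopentylmethyl and methylcarbamoyl rank against each other therefore stays open. Also open, going by these compounds, is whether bromo, an amine or a carboxylic acid in place of chloro would give a low number like that of compound 1 or a high one like those of the other three compounds.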